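The source may hold more compounds than are shown below. What is called first, only, known or untested is meant among the compounds shown, and "the series" means these compounds.

Compound 1 `C/C1=C\CC[C@@]2(C)O[C@@H]2[C@H]2OC(=O)[C@@H](CN3CCCC3)[C@@H]2C[C@H]1O`: 4000 nM
Compound 2 `C/C1=C\CC[C@@]2(C)O[C@@H]2[C@H]2OC(=O)[C@@H](CN3CCN(C)CC3)[C@@H]2C[C@H]1O`: 25000 nM

Both values come from a functional assay on B16-F10 cells (Mus musculus) for inhibition, read by colorimetric assay and MTT assay, with a stated time of 72 h (on this read-out lower numbers stand for stronger inhibition and higher numbers for weaker inhibition), and the lower number of the two belongs to compound 1. Among the measured compounds shown here, the only measured step is a 6.3-fold higher number from compound 1 to compound 2 (0.80 log units; beyond the scatter). It replaces pyrrolidin-1-yl with 4-methylpiperazin-1-yl on a saturated chain carbon bound to a saturated ring carbon.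

Compound 3 `C/C1=C\CC[C@@]2(C)O[C@@H]2[C@H]2OC(=O)[C@@H](CN3CCCC3)[C@@H]2C[C@@H]1O` has not yet been measured in this assay. For the measured compounds named here, its relation to the first compound in the list is the two compounds have the same atoms and bonds and differ only in configuration as drawn: 1 of 7 stereo elements differ; a stereocentre at a saturated ring carbon is drawn R in compound 1 and S in compound 3. Going by the values given here, the pyrrolidin-1-yl group is therefore shared, and no measured step covers a change of configuration. Among the compounds with values here, the single step above concerns a different change, so it offers only a rough scale and no direction.

A step no larger than that one is expected, quite possibly within the scatter. Any lean towards a higher number is tentative and rests only on compound 1, at 4000 nM, holding the lower of the two values. The expected step is a 1.5-fold higher number from compound 1 to compound 3 (0.18 log units; within the scatter). For compound 3 the estimated value is 6000 nM, with an expected range from 2000 nM to 18000 nM.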

Compound 3, half-maximal inhibitory concentration: 7000 nM
Compound 3: the middle estimate sits 1.2-fold (0.07 log units) below what was measured, within the range that was stated.
By their numbers in this assay, from the lowest: compounds 1 and 3 (each within the scatter of the next); then compound 2.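

In this assay, the new result gives the first measure of what configuration does at this saturated ring carbon with the pyrrolidin-1-yl group held constant: a 1.8-fold higher number from compound 1 to compound 3 (0.24 log units; within the scatter). Redrawing this one stereocentre from R to S therefore leaves compound 1 and compound 3 indistinguishable on this read-out, whereas the exchange of pyrrolidin-1-yl for 4-methylpiperazin-1-yl, a 6.3-fold higher number from compound 1 to compound 2 (0.80 log units; beyond the scatter), is a step beyond the scatter. This makes the amine the only change shown so far to separate compounds in this assay, and the reading for configuration is a clean one, applying to this single stereocentre alone: the fact that compounds 1 and 3 differ only in the configuration as drawn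

The compounds shown leave open whether this stereocentre would count for as little if the R and S forms carried 4-methylpiperazin-1-yl in place of pyrrolidin-1-yl. They also leave open how other amines on the same saturated chain carbon, such as morpholin-4-yl or an open-chain dimethylamino group, would read in this assay, and so whether pyrrolidin-1-yl holds any particular standing among amines there.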